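The source may report more compounds than this note shows. Statements on the series, on what has been measured and on what is new or still open speak of the compounds shown alone.

Measured so far:
compound 1 `Clc1ccc(Cc2nn3cc(-c4ccc(Br)cc4)nc3s2)cc1` — in a functional assay on HeLa cells (Homo sapiens) for cytotoxicity, with a stated time of 72 h (a lower number here means a stronger inhibitor, a higher number a weaker inhibitor), compound 1 gives > 250000 nM, which is a limit of the assay.
compound 2 `Clc1ccc(Cc2nn3cc(-c4ccc(Cl)cc4Cl)nc3s2)cc1` — in this assay compound 2 gives 109000 nM.
compound 3 `Clc1ccc(Cc2nn3c(Br)c(-c4ccc(Br)cc4)nc3s2)cc1` — in this assay compound 3 gives 188000 nM.

Compound 3 holds the highest of the two numbers; compound 2 sits within the scatter of it, and compound 1 gives only a limit. Compound 4 `Clc1ccc(Cc2nn3c(Br)c(-c4ccccc4)nc3s2)cc1` differs from compound 3 by hydrogen in place of bromo on an aromatic carbon. Going by the values given here, no measured step makes this exact exchange. The nearest are an at least 2.2-fold lower number from compound 1 to compound 2 (0.36 log units; beyond the scatter), a change on the same ring, and an at least 1.3-fold lower number from compound 1 to compound 3 (0.12 log units; that floor lies within the scatter), the reverse exchange on another position; for compound 1 the starting value is the limit (the limit of > 250000 nM in this assay, at which 1 of the 3 values shown sits). Hydrogen in place of bromo on that ring is therefore expected to give no more than a small rise, a 1.3-fold higher number from compound 3 to compound 4 (0.12 log units; within the scatter). Compound 4 is estimated at 250000 nM, range 100000 nM to 600000 nM, with a fair chance of only a limit.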

Compound 4, half-maximal inhibitory concentration: > 250000 nM
Compound 4: no number, only a limit; the forecaster's own chance of this, stated with the estimate: 45%; the middle value lies on the limit itself.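

Going by these compounds alone, the exchange of 4-bromophenyl to phenyl, para to a large group, is the only step here confined to this position. In this assay it reads an at least 1.3-fold higher number from compound 3 to compound 4 (0.12 log units; that floor lies within the scatter) and so gives a floor only, leaving the true size of the change unknown. Compound 4 gives > 250000 nM as a limit of the assay, and this limit is now shared: the limit of > 250000 nM in this assay, at which 2 of the 4 values shown sit.

Still open, from the compounds shown here alone, is whether an amine or a carboxylic acid in place of the bromo would give a number clearly lower than those seen so far. Going by these compounds, the effect of either group on the core's bromo-bearing position also remains unknown.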